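Benzoyl for acetyl on the vinyl sulfone side chain

The compounds below may be only part of what the source reports. "The series", "measured", "known", "first", "only" and "open" are said of these compounds alone.

Measured so far:
Compound 1, `CCOC(=O)C(=Cc1c(-c2ccccc2)[nH]c2ccccc12)C(=O)OCC`, 7000 nM in a functional assay on SNB-75 cells (Homo sapiens) for inhibition, read by sulforhodamine B assay, with a stated time of 48 h; on this read-out lower numbers stand for stronger inhibition of growth and higher numbers for weaker inhibition of growth.
Compound 2, `CC(=O)/C(=C\c1c(-c2ccccc2)[nH]c2ccccc12)S(=O)(=O)c1ccccc1`, 1700 nM in this assay.

Of the compounds shown here, two sharing the same core have been measured. In this assay compound 1 gives 7000 nM, while compound 2 gives 1700 nM. Compound 2 therefore has the lower of the two numbers, and its gap to compound 1 is beyond the usual scatter of this kind of measurement. The two compounds differ in more than one place, so the numbers speak only for themselves and no single change can be credited.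

Compound 3, `O=C(/C(=C\c1c(-c2ccccc2)[nH]c2ccccc12)S(=O)(=O)c1ccccc1)c1ccccc1`, has not yet been measured in this assay. It differs from compound 2 in one place: phenyl in place of methyl on a carbonyl carbon, acetyl to benzoyl. No measured pair shows this change, so there is no precedent among these compounds for its size or direction. The expectation is a step of a 1.1-fold lower number from compound 2 to compound 3 (0.05 log units; within the scatter), within the scatter. Compound 3 is estimated at 1500 nM, in the range 500 nM to 4500 nM.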

Compound 3, concentration for 50% growth inhibition: 10100 nM
The estimate for compound 3 lay 6.7-fold (0.83 log units) below the measured number; measured number outside the range, above it.
By their numbers in this assay, from the lowest: compound 2; then compounds 1 and 3 (each within the scatter of the next).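

Phenyl in place of methyl on a carbonyl carbon, acetyl to benzoyl, gives a 5.9-fold higher number from compound 2 to compound 3 (0.77 log units; beyond the scatter) in this assay, so what this carbonyl carbon carries clearly matters to inhibition of growth in these cells. This is the first pair among these compounds that differs in one place, and it gives a size and a direction for a change at this position, which compound 1 and compound 2 could not give because they differ in more than one place. Nothing among the data shown offers an explanation for this step.

The compounds shown leave open whether the loss belongs to the aromatic ring itself or would also follow from any group other than methyl on this carbonyl carbon, since only these two groups can be compared here. An ethyl or a cyclopropyl group would help to separate these two readings, and a phenyl ring bearing a methoxy group or an amine would show whether the benzoyl compound can be improved by substitution on its ring.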